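Acylprolinamide replacements on a piperidine sulfonamide series

A few compounds are considered here, and "the series" means these few. Any claim that something is new, unique, unknown or untested is made for them only; others in the source may bear on it.

Measured compounds:
compound 1, `O=C(CN1CCCC1)N1CCC(NS(=O)(=O)c2cc(S(=O)(=O)c3ccccc3)ccc2C(F)(F)F)CC1`, 110 nM in an assay on isolated protein for binding affinity to secreted frizzled-related protein 1 (Homo sapiens), read by fluorescence; on this read-out lower numbers stand for stronger inhibition and higher numbers for weaker inhibition
compound 2, `CC(C)C(=O)N1CCC[C@H]1C(=O)N1CCC(NS(=O)(=O)c2cc(S(=O)(=O)c3ccccc3)ccc2C(F)(F)F)CC1`, 40 nM in this assay
compound 3, `CC(C)(C)C(=O)N1CCC[C@H]1C(=O)N1CCC(NS(=O)(=O)c2cc(S(=O)(=O)c3ccccc3)ccc2C(F)(F)F)CC1`, 40 nM in this assay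

Compound 1 gives the highest number of the three. The two changes made from it both move the read-out the same way: a 2.8-fold lower number from compound 1 to compound 2 (0.44 log units; beyond the scatter) and a 2.8-fold lower number from compound 1 to compound 3 (0.44 log units; beyond the scatter), each a modest step beyond the scatter. Between compound 2 and compound 3 there is no change at the digits printed from compound 2 to compound 3 (within the scatter), so the extra branching on the acyl side chain is not registered at this read-out.

Compound 4 is `CC(C)(C)CC(=O)N1CCC[C@H]1C(=O)N1CCC(NS(=O)(=O)c2cc(S(=O)(=O)c3ccccc3)ccc2C(F)(F)F)CC1`. Relative to compound 1 the change is 1-(neopentylcarbonyl)pyrrolidin-2-yl in place of (pyrrolidin-1-yl)methyl on a carbonyl carbon. It is the same kind of change as in the step to compound 2 and in the step to compound 3, with a chain one carbon longer than either. Both of those steps lowered the number to the same extent, and the difference between them was within the scatter. The expectation is therefore a step of similar size and direction, a 2.8-fold lower number from compound 1 to compound 4 (0.44 log units; beyond the scatter), with no basis for expecting anything beyond that. Compound 4 is estimated at 40 nM in this assay, with a range of 20 nM to 90 nM.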

Compound 4, half-maximal inhibitory concentration: 20 nM
Compound 4: middle estimate off by 2.0-fold (0.30 log units), on the high side; low and high end bracket the measured number.
By their numbers in this assay, from the lowest: compounds 4, 2 and 3 (each within the scatter of the next); then compound 1.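

Compound 4 carries the 1-(neopentylcarbonyl)pyrrolidin-2-yl group on the carbonyl carbon and shows that the gain over (pyrrolidin-1-yl)methyl in this assay holds with a chain one carbon longer, with a 5.5-fold lower number from compound 1 to compound 4 (0.74 log units; beyond the scatter) as the step. Neopentyl in place of tert-butyl gives a 2.0-fold lower number from compound 3 to compound 4 (0.30 log units; within the scatter) and neopentyl in place of isopropyl gives a 2.0-fold lower number from compound 2 to compound 4 (0.30 log units; within the scatter) and since both lie within the scatter, the three acyl groups are not separated at this read-out and the added length carries no measurable penalty here. Nothing available explains why this position accepts all three acyl groups.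

Going by these compounds, it remains open how far this flat stretch extends, and whether a longer chain such as hexanoyl, a benzoyl group, or an acyl chain ending in a carboxylic acid or an amine would separate from these three compounds. Also open, on these data alone, is how much of the step from compound 1 belongs to the acyl group and how much to the ring itself, a question that an unacylated pyrrolidin-2-yl group or the opposite configuration at the defined stereocentre would address.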